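Swapping one phenyl group: compound 3 to compound 4

The source may report more compounds than this note shows. Statements on the series, on what has been measured and on what is new or still open speak of the compounds shown alone.

Going by the values given here, in a functional assay on UACC-62 cells (Homo sapiens) (a lower number here means a stronger inhibitor of growth, a higher number a weaker inhibitor of growth), compound 3 `O=S(=O)(/C=C/c1ccc(C(F)(F)F)cc1F)Cc1ccc(Nc2ncnc3ccccc23)cc1` gives 100000 nM, the higher of the two exact numbers so far. Compound 1 `O=S(=O)(/C=C/c1ccc(Cl)cc1Cl)Cc1ccc(Nc2ncnc3ccccc23)cc1` gives 2000 nM. Compound 2 `O=S(=O)(/C=C/c1ccc(F)cc1F)Cc1ccc(Nc2ncnc3ccccc23)cc1` gives > 100000 nM, and this is a limit of the assay, not a number.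

Still unmeasured is compound 4 `O=S(=O)(/C=C/c1ccc(O)cc1)Cc1ccc(Nc2ncnc3ccccc23)cc1`. The change is 4-hydroxyphenyl in place of 2-fluoro-4-(trifluoromethyl)phenyl on a double-bonded chain carbon bound to a double-bonded chain carbon: 4-hydroxyphenyl in place of 2-fluoro-4-(trifluoromethyl)phenyl, on a double-bonded chain carbon bound to a double-bonded chain carbon.

The most relevant steps altered this same group. Both a 50-fold higher number from compound 1 to compound 3 (1.70 log units; beyond the scatter) and an at least 50-fold higher number from compound 1 to compound 2 (1.69 log units; beyond the scatter) were large, so a change here can move the number a long way. The remaining step, a number no higher from compound 2 to compound 3 (the limit leaves the size open), has no readable size. Among the compounds with values here, no measured compound carries 4-hydroxyphenyl, so the size of the next step is uncertain. Compound 3 stands at the top of the exact numbers, so a lower number is the likelier direction. The expected result is a 4.0-fold lower number from compound 3 to compound 4 (0.60 log units; beyond the scatter). For compound 4, the estimate is 25000 nM, with an expected range of 3000 nM to 100000 nM.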

Compound 4, concentration for 50% growth inhibition: 100000 nM
Beside the measured number, compound 4's estimate is 4.0-fold (0.60 log units) below it; the range from low to high includes it.
By their numbers in this assay, from the lowest: compound 1; then compounds 3 and 4 (each within the scatter of the next).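

In this assay, 4-hydroxyphenyl, with a hydrogen-bond donor, and 2-fluoro-4-(trifluoromethyl)phenyl, with none and more heavy atoms, read alike at this position on the double-bonded chain carbon: the result is no change at the digits printed from compound 3 to compound 4 (within the scatter). So adding a hydroxyl group and removing all the fluorine does not bring back the stronger growth inhibition of the 2,4-dichlorophenyl compound, as a 50-fold higher number from compound 1 to compound 4 (1.70 log units; beyond the scatter) shows. Compound 2 carries a limit, not a number, so its step to compound 4 cannot be read: the limit of > 100000 nM in this assay, at which 1 of the 4 values shown sits.

As far as these compounds go, with only a number no higher from compound 2 to compound 4 (the limit leaves the size open) to go on for that step, it remains open whether a single chloro group, as in 4-chlorophenyl, would be enough to give a number near that of compound 1. Also open, from the compounds shown here alone, is how a larger halogen pair, as in 2,4-dibromophenyl, or an amine, as in 4-aminophenyl, would behave here.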